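Swapping the bicyclic amide in a sulfonyl benzylamide series

The source may hold more compounds than are shown below. What is called first, only, known or untested is meant among the compounds shown, and "the series" means these compounds.

Of the compounds shown here, three have been measured in an assay for inhibition of Nicotinamide phosphoribosyltransferase (Homo sapiens), read by mass spectrometry, with stated times of 15 min and 30 min; a higher number here means a weaker inhibitor, a lower number a stronger inhibitor. Compound 1 `O=C(NCc1ccc(S(=O)(=O)c2ccccc2)cc1)c1cc2ncccc2s1` gives 400 nM. Compound 2 `O=C(Nc1ccc(S(=O)(=O)N2CCCCC2)cc1)c1cc2cnccc2[nH]1` reaches only the limit of the assay, > 10000 nM, so no number is known for it (the limit of > 10000 nM in this assay, at which 1 of the 3 values shown sits). Compound 3 `O=C(NCc1ccc(S(=O)(=O)N2CCCCC2)cc1)c1cc2cnccc2o1` gives 140 nM, the lower of the two numbers; its gap to compound 1 lies beyond the usual scatter. Compound 4 `O=C(NCc1ccc(S(=O)(=O)N2CCCCC2)cc1)c1ccc2nc[nH]c2c1` is not yet measured. It differs from compound 3 in one place: a group of 9 heavy atoms (7 carbon, 2 nitrogen; one five-membered aromatic ring with 2 hetero atoms, one six-membered aromatic ring of carbon only) in place of a group of 9 heavy atoms (7 carbon, 1 nitrogen, 1 oxygen; one five-membered aromatic ring with 1 hetero atom, one six-membered aromatic ring with 1 hetero atom), on a carbonyl carbon, a group of 9 heavy atoms (7 carbon, 2 nitrogen; one five-membered aromatic ring with 2 hetero atoms, one six-membered aromatic ring of carbon only) in place of a group of 9 heavy atoms (7 carbon, 1 nitrogen, 1 oxygen; one five-membered aromatic ring with 1 hetero atom, one six-membered aromatic ring with 1 hetero atom), on a carbonyl carbon. Going by the values given here, no measured pair shows this change, so its size is unknown; a loss of potency beyond the scatter is expected, with the step from compound 3 to compound 4 estimated at an 11-fold higher number from compound 3 to compound 4 (1.03 log units; beyond the scatter). Compound 4 is expected to give about 1500 nM, within 300 nM to 8000 nM.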

Compound 4, half-maximal inhibitory concentration: 310 nM
The estimate for compound 4 lay 4.8-fold (0.68 log units) above the measured number; low and high end bracket the measured number.
By their numbers in this assay, from the lowest: compound 3; then compounds 4 and 1 (each within the scatter of the next). At a limit, above all of these: compound 2.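

Within this assay this first pair differing in one place only gives a 2.2-fold higher number from compound 3 to compound 4 (0.35 log units; beyond the scatter) when 1H-benzimidazol-6-yl replaces the group on the carbonyl carbon. The position therefore accepts a different pair of fused rings, one with a six-membered aromatic ring of carbon only and 1 hydrogen-bond donor, at a modest loss rather than a collapse. Nothing measured here explains the size of this step.

The swap alters several features at once, so this single step cannot show whether the loss follows the oxygen, the nitrogen in the six-membered ring or the added hydrogen-bond donor. Also open, as far as these compounds go, is how compound 4 would respond to a methyl on a ring nitrogen of the benzimidazole or a fluorine on its six-membered ring.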